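Benzylamine aryl variation on the shared core: compound 3

A few compounds are considered here, and "the series" means these few. Any claim that something is new, unique, unknown or untested is made for them only; others in the source may bear on it.

Compound 1 `Nc1cc(N)c2nc(-c3ccccc3)c(NCc3ccc(Cl)c(Cl)c3)nc2c1` and compound 2 `COc1ccc(CNc2nc3cc(N)cc(N)c3nc2-c2ccccc2)cc1OC` were both tested in a functional assay on SNB-19 cells (Homo sapiens) for inhibition, read by sulforhodamine B assay, with a stated time of 48 h; on this read-out higher numbers stand for lower toxicity in this test and lower numbers for higher toxicity in this test. For compound 1 only a limit of the assay is recorded, < 100000 nM. For compound 2 likewise only a limit of the assay is recorded, < 100000 nM. The step that the two limits leave unreadable from compound 1 to compound 2 stays unreadable because of the limit of < 100000 nM in this assay, at which 2 of the 2 values shown sit. Compound 3 `Nc1cc(N)c2nc(-c3ccccc3)c(NCc3ccc(F)cc3)nc2c1` has not yet been measured; it differs from compound 2 by 4-fluorophenyl in place of 3,4-dimethoxyphenyl on a saturated chain carbon bound to a nitrogen on an aromatic ring. Going by the values given here, no measured step bears on this change, as both recorded values are limits. The expected step is a step that the limit leaves unreadable from compound 2 to compound 3, small. Compound 3 is estimated at 30000 nM, in a range from 5000 nM to 100000 nM.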

Compound 3, concentration lethal to 50% of the cells: 52500 nM
For compound 3 the middle estimate is 1.8-fold (0.24 log units) below the measured one; low and high end bracket the measured number.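

Going by these compounds alone, no step to compound 3 can be read from compound 1 or compound 2, since both of those values are limits: the limit of < 100000 nM in this assay, at which 2 of the 3 values shown sit. The compounds shown leave open how large any step among compound 1, compound 2 and compound 3 is in this assay.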